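Bromo to Methyl: An Expected Shift in Partition

The source may report more compounds than this note shows. Statements on the series, on what has been measured and on what is new or still open speak of the compounds shown alone.

Compounds measured in a physicochemical assay for lipophilicity, measured as octanol-water partition; a higher number here means a more lipophilic compound, a lower number a more polar compound
compound 1 `O=C(NNc1ccnc2cc(Cl)ccc12)c1ccccc1/N=C/c1ccc(F)cc1` gives 5.18
compound 2 `O=C(NNc1ccnc2cc(Cl)ccc12)c1ccccc1/N=C/c1ccccc1Cl` gives 5.5
compound 3 `O=C(NNc1ccnc2cc(Cl)ccc12)c1ccccc1/N=C/c1ccc(Br)cc1` gives 5.76

Compound 3 gives 5.76, and it shares the upper end of this small set, the measured gap being a number 0.26 log units higher from compound 2 to compound 3 (within the scatter). The lower end stands apart, with a number 0.58 log units higher from compound 1 to compound 3 (beyond the scatter).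

Compound 4 `Cc1ccc(/C=N/c2ccccc2C(=O)NNc2ccnc3cc(Cl)ccc23)cc1` has not yet been measured in this assay. It keeps the shared core and differs at one place (methyl in place of bromo on an aromatic carbon), with methyl in place of bromo on an aromatic carbon, para to a large group.

The closest guide is the modest step already seen at this place, bromo in place of fluoro, which reads a number 0.58 log units higher from compound 1 to compound 3 (beyond the scatter). Going by the values given here, no measured compound carries a methyl, so the size of the new step remains uncertain. A downward step smaller than that one, near the edge of the scatter, is expected.

The expected step is a number 0.26 log units lower from compound 3 to compound 4 (within the scatter).

For compound 4 the estimated value is 5.5, with an expected range from 5.15 to 5.8.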

Compound 4, partition coefficient: 5.31
The estimate for compound 4 lay 0.19 log units above the measured number, within the range that was stated.
By their numbers in this assay, from the lowest: compounds 1, 4, 2 and 3 (each within the scatter of the next, the first and the last beyond it).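

At this position, on an aromatic carbon para to a large group, methyl in place of bromo moves the reading in this assay by a step beyond the scatter (a number 0.45 log units lower from compound 3 to compound 4 (beyond the scatter)). Methyl therefore does not stand with bromo here: it cannot be told apart from fluoro (a number 0.13 log units higher from compound 1 to compound 4 (within the scatter)), and the 4-methylphenyl compound also cannot be told apart from the 2-chlorophenyl compound (a number 0.19 log units lower from compound 2 to compound 4 (within the scatter)). No measurement shown here bears on what lies behind these steps.

The compounds shown leave open how an ethyl, a methoxy or an amine at this same place would read against methyl and bromo. They also leave open whether the step from bromo to methyl would keep its size on a different core.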